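Cytotoxicity in the benzylated piperazinone series: amine variation

The compounds below may be only part of what the source reports. "The series", "measured", "known", "first", "only" and "open" are said of these compounds alone.

Compound 1 `COc1ccc2[nH]c(C(=O)N3CC(=O)N(Cc4ccccc4)[C@@H](COc4ccccc4)C3)cc2c1` carries a phenoxy group on the saturated chain carbon bound to a saturated ring carbon. In an ADME assay on Vero cells (Chlorocebus sabaeus) for cytotoxicity, with a stated time of 7 days (on this read-out lower numbers stand for higher toxicity in this test and higher numbers for lower toxicity in this test), compound 1 reaches only the limit > 10000 nM. Compound 2 `COc1ccc2[nH]c(C(=O)N3CC(=O)N(Cc4ccccc4)[C@@H](CN4CCN(c5ccccn5)CC4)C3)cc2c1` likewise gives only a limit, > 30000 nM, in this assay. Among the measured compounds shown here, compound 3 `COc1ccc2[nH]c(C(=O)N3CC(=O)N(Cc4ccccc4)[C@@H](CN4CCC(C(C)C)CC4)C3)cc2c1` is the only member of the three with a number rather than a limit, giving 3800 nM in this assay. The step that the two limits leave unreadable from compound 1 to compound 2 cannot be read. The steps of an at least 2.6-fold lower number from compound 1 to compound 3 (0.42 log units; beyond the scatter) and an at least 7.8-fold lower number from compound 2 to compound 3 (0.89 log units; beyond the scatter) both point to lower numbers for the amine with the aliphatic ring, but each is bounded only by a limit; the limits the limit of > 10000 nM in this assay, at which 1 of the 3 values shown sits, and the limit of > 30000 nM in this assay, at which 1 of the 3 values shown sits, set how far they can be read.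

Compound 4 `COc1ccc2[nH]c(C(=O)N3CC(=O)N(Cc4ccccc4)[C@@H](CN4CCc5ccccc5C4)C3)cc2c1` carries the change (1,2,3,4-tetrahydroisoquinolin-2-yl in place of 4-isopropylpiperidin-1-yl on a saturated chain carbon bound to a saturated ring carbon). For the measured compounds named here, no measured step exchanges one tertiary amine for another, so the two readable steps give only an outer frame. No step beyond the scatter is expected, so a 1.1-fold higher number from compound 3 to compound 4 (0.02 log units; within the scatter) is the estimate. Compound 4 is expected to give 4000 nM in this assay, within 1500 nM to 12000 nM.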

Compound 4, half-maximal cytotoxic concentration: 51800 nM
Compound 4: middle estimate off by 13-fold (1.11 log units), on the low side; measured number above the stated range.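

At this position, on a saturated chain carbon bound to a saturated ring carbon, exchanging one tertiary amine for another is enough to move the read-out strongly in this assay: 1,2,3,4-tetrahydroisoquinolin-2-yl in place of 4-isopropylpiperidin-1-yl gives a 14-fold higher number from compound 3 to compound 4 (1.13 log units; beyond the scatter). Among the compounds shown here, this is the first step with a number at both ends, and it shows that an amine on this carbon does not by itself bring the number down, since compound 4 carries one too. The steps from compound 1 and from compound 2 to compound 4 cannot be read; those two compounds stand only as limits.

As far as these compounds go, how much of the step goes with the aromatic ring that enters and how much with the isopropyl group that leaves remains open. Unsubstituted piperidin-1-yl or 4-phenylpiperidin-1-yl on the same carbon would separate the two.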